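Tetrabromo series: aryl versus methyl on the carbinol carbon

The source may report more compounds than this note shows. Statements on the series, on what has been measured and on what is new or still open speak of the compounds shown alone.

In a functional assay on MCF7 cells (Homo sapiens) for antiproliferative activity, read by MTT assay, with a stated time of 24 h, tested at 25 uM (a higher number here means a weaker effect of the compound at the concentration tested, a lower number a stronger effect), compound 3 `CC(O)CCn1nc2c(Br)c(Br)c(Br)c(Br)c2n1` gives 102%, the highest of the three numbers; compound 2 `OC(CCn1nc2c(Br)c(Br)c(Br)c(Br)c2n1)c1ccccc1` gives 99%, and compound 1 `COc1cccc(C(O)CCn2nc3c(Br)c(Br)c(Br)c(Br)c3n2)c1` gives 71%. The step of a number 3 percentage points higher from compound 2 to compound 3 (within the scatter) lies within the scatter, whereas a number 31 percentage points higher from compound 1 to compound 3 (beyond the scatter) and a number 28 percentage points higher from compound 1 to compound 2 (beyond the scatter) lie beyond it. Compound 4 `OC(CCn1nc2c(Br)c(Br)c(Br)c(Br)c2n1)c1ccc(Cl)cc1` differs from compound 3 by 4-chlorophenyl in place of methyl on a saturated chain carbon bound to an oxygen on a saturated carbon and a saturated chain carbon. The step from methyl to plain phenyl, a number 3 percentage points higher from compound 2 to compound 3 (within the scatter), gave no shift beyond the scatter, while the methoxy-bearing aryl of compound 1 sits at 71%. A chlorine-bearing aryl is expected to fall between these, so a downward step a number 17 percentage points lower from compound 3 to compound 4 (beyond the scatter) is estimated. Compound 4 is expected to give 85%, within 60% to 105%.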

Compound 4, a percentage reported as activity, at one concentration (the size of the read-out at that concentration, not a potency): 96%
Compound 4: middle estimate off by 11 percentage points, on the low side, within the range that was stated.
By their numbers in this assay, from the lowest: compound 1; then compounds 4, 2 and 3 (each within the scatter of the next).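

At this position, 4-chlorophenyl in place of methyl gives a number 6 percentage points lower from compound 3 to compound 4 (within the scatter) and chloro in place of hydrogen on an aromatic carbon gives a number 3 percentage points lower from compound 2 to compound 4 (within the scatter), so neither the chlorine nor the aryl ring separates these compounds. The separation remains with the 3-methoxyphenyl group, as a number 25 percentage points higher from compound 1 to compound 4 (beyond the scatter) shows, and not with aryl groups in general. No evidence on the cause is at hand. Open, as far as these compounds go, is whether an amine or a carboxylic acid on the aromatic ring would match methoxy, and what a longer chain in place of methyl would give.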